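Compound 4: one fluorine in place of two chlorines

This account rests on a few compounds, and the source may have more. Where it says the series, first, only, none or still open, it means among the compounds named here.

Compound 1 `COC(=O)C1=C(C)N=C(C)/C(=C(\O)OC)C1c1cccc(O)c1` gives 1000 nM in a functional assay (muscle tissue) with Cavia porcellus as the target; on this read-out lower numbers stand for an effect already at smaller amounts and higher numbers for an effect only at larger amounts of compound.
Compound 2 `COC(=O)C1=C(C)N=C(C)/C(=C(\O)OC)C1c1cccc(C)c1` gives 110 nM in this assay.
Compound 3 `COC(=O)C1=C(C)N=C(C)/C(=C(\O)OC)C1c1cccc(Cl)c1Cl` gives 19.1 nM in this assay.

Compound 3 holds the lowest number of the three: compound 2 is nearest, a 5.8-fold lower number from compound 2 to compound 3 (0.76 log units; beyond the scatter), and compound 1 furthest, a 52-fold lower number from compound 1 to compound 3 (1.72 log units; beyond the scatter). Compound 4 `COC(=O)C1=C(C)N=C(C)/C(=C(\O)OC)C1c1cccc(F)c1` differs from compound 3 in one place: 3-fluorophenyl in place of 2,3-dichlorophenyl on a saturated ring carbon. Both steps toward compound 3 bear on this change, since each replaced a single substituent on the phenyl ring with 2,3-dichlorophenyl and lowered the number, modestly from compound 2 and strongly from compound 1. The 3-fluorophenyl of compound 4 resembles the 3-methylphenyl of compound 2 more than the 2,3-dichlorophenyl, so a modest rise is expected, a 6.8-fold higher number from compound 3 to compound 4 (0.83 log units; beyond the scatter). Compound 4 is therefore estimated at 130 nM, in the range 40 nM to 400 nM.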

Compound 4, half-maximal effective concentration: 20.9 nM
The estimate for compound 4 lay 6.2-fold (0.79 log units) above the measured number; the whole stated range lies above it.
By their numbers in this assay, from the lowest: compounds 3 and 4 (each within the scatter of the next); then compound 2; then compound 1.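

In this assay, a single fluorine on the phenyl ring matches two chlorines, with a 1.1-fold higher number from compound 3 to compound 4 (0.04 log units; within the scatter), so the second ring substituent is not needed to reach this level. Among single substituents, the identity of the group matters strongly, with a 5.3-fold lower number from compound 2 to compound 4 (0.72 log units; beyond the scatter) and a 48-fold lower number from compound 1 to compound 4 (1.68 log units; beyond the scatter). Nothing available explains these differences. Still open, going by these compounds, is how an amine or a carboxylic acid in place of the fluoro would read out, and whether 3-chlorophenyl would match 3-fluorophenyl.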